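The source may hold more compounds than are shown below. What is called first, only, known or untested is meant among the compounds shown, and "the series" means these compounds.

Compound 1 `CN(C)C(=O)c1cc2cnc(Nc3ccc(NC(=O)C4(C(=O)Nc5cccc(F)c5)CC4)cc3)nc2n1C1CCCC1` is the starting point. Among the measured compounds shown here, in a functional assay on A549 cells (Homo sapiens) for inhibition, read by CCK-8 assay, with a stated time of 72 h, tested at 1 uM (a lower number here means less inhibition of growth, a higher number more inhibition of growth at the concentration tested), compound 1 gives 33.2%, the second highest of the three numbers measured so far. Compound 2 `COc1ccc(NC(=O)C2(C(=O)Nc3ccc(Nc4ncc5cc(C(=O)N(C)C)n(C6CCCC6)c5n4)cc3)CC2)cc1` carries a 4-methoxyphenyl on the same amide-type nitrogen, and in this assay compound 2 gives 74.4%. Compound 3 `CN(C)C(=O)c1cc2cnc(Nc3ccc(NC(=O)C4(C(=O)Nc5ccc(Cl)c(C(F)(F)F)c5)CC4)cc3)nc2n1C1CCCC1` carries a 4-chloro-3-(trifluoromethyl)phenyl there, and in this assay compound 3 gives 1.1%. The step of a number 41.2 percentage points higher from compound 1 to compound 2 (beyond the scatter) shows how far a methoxy on that ring can lift the number, while a number 32.1 percentage points lower from compound 1 to compound 3 (beyond the scatter) shows the other direction. Compound 4 `COc1cccc(NC(=O)C2(C(=O)Nc3ccc(Nc4ncc5cc(C(=O)N(C)C)n(C6CCCC6)c5n4)cc3)CC2)c1` has not been measured yet; it differs from compound 1 as follows: methoxy in place of fluoro on an aromatic carbon. For the measured compounds named here, the only measured step in which a methoxy enters is the one to compound 2, which gives 4-methoxyphenyl rather than 3-methoxyphenyl, so the size of the effect here is uncertain. A rise in this assay is expected, smaller than that step, as a number 21.8 percentage points higher from compound 1 to compound 4 (beyond the scatter). For compound 4 the estimate in this assay is 55%, between 30% and 80%.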

Compound 4, percent growth inhibition at one concentration: 77.2%
For compound 4 the middle estimate is 22.2 percentage points below the measured one; the measured number falls inside the stated range.
By their numbers in this assay, from the lowest: compound 3; then compound 1; then compounds 2 and 4 (each within the scatter of the next).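

In this assay, the new result shows that the methoxy effect is not tied to one spot on the ring: a number 2.8 percentage points higher from compound 2 to compound 4 (within the scatter), so 3-methoxyphenyl and 4-methoxyphenyl cannot be told apart here. Among the compounds shown here, with the group's place held fixed, methoxy in place of fluoro gives a number 44 percentage points higher from compound 1 to compound 4 (beyond the scatter), the first step that isolates the identity of the group on this ring. Replacing 4-chloro-3-(trifluoromethyl)phenyl with 3-methoxyphenyl gives a number 76.1 percentage points higher from compound 3 to compound 4 (beyond the scatter), confirming how wide the range at this amide-type nitrogen is.

Nothing available here explains these steps. From the compounds shown here alone, it remains open whether the oxygen of the methoxy matters, which a hydroxy, ethoxy or plain methyl at the same place on the ring could test.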